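Aryl change on the shared core: compound 3 to compound 4

The source may report more compounds than this note shows. Statements on the series, on what has been measured and on what is new or still open speak of the compounds shown alone.

In a functional assay on OVCAR-3 cells (Homo sapiens) for inhibition, read by MTT assay, with a stated time of 24 h (on this read-out higher numbers stand for weaker inhibition and lower numbers for stronger inhibition), compound 1 `CC1(C)[C@H]2CC[C@]1(C)N(Cc1cn(-c3ccc(C#N)cc3)nn1)C(=O)C2` gives 380 nM, compound 2 `Cc1ccccc1-n1cc(CN2C(=O)C[C@@H]3CC[C@@]2(C)C3(C)C)nn1` gives 150 nM and compound 3 `COc1ccc(-n2cc(CN3C(=O)C[C@@H]4CC[C@@]3(C)C4(C)C)nn2)cc1` gives 250 nM. Compound 3 lies within the scatter of both others: the data show a 1.5-fold lower number from compound 1 to compound 3 (0.18 log units; within the scatter) and a 1.7-fold higher number from compound 2 to compound 3 (0.22 log units; within the scatter). Only a 2.5-fold lower number from compound 1 to compound 2 (0.40 log units; beyond the scatter) goes beyond the scatter, and it is modest.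

The next compound is compound 4 `Cc1cccc(-n2cc(CN3C(=O)C[C@@H]4CC[C@@]3(C)C4(C)C)nn2)c1`, with 3-methylphenyl in place of 4-methoxyphenyl on an aromatic nitrogen. Among the measured compounds shown here, no measured compound carries 3-methylphenyl. For the measured compounds named here, the closest precedent is compound 2, which also has a methylphenyl group, and its swap to 4-methoxyphenyl gave a 1.7-fold higher number from compound 2 to compound 3 (0.22 log units; within the scatter). That step is small, so the change at hand is not expected to move the number beyond the scatter in this assay. Any drift is expected towards the lower numbers. The expected step is a 1.3-fold lower number from compound 3 to compound 4 (0.10 log units; within the scatter). The estimate for compound 4 is 200 nM, with an expected range of 100 nM to 400 nM.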

Compound 4, half-maximal inhibitory concentration: 160 nM
Estimate against measurement, compound 4: 1.3-fold (0.10 log units) above, within the range that was stated.
By their numbers in this assay, from the lowest: compounds 2, 4, 3 and 1 (each within the scatter of the next, the first and the last beyond it).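

In this assay, 3-methylphenyl on the aromatic nitrogen cannot be told apart from 4-methoxyphenyl, with a 1.6-fold lower number from compound 3 to compound 4 (0.19 log units; within the scatter), or from 2-methylphenyl, with a 1.1-fold higher number from compound 2 to compound 4 (0.03 log units; within the scatter), so the two methylphenyl groups read alike at this position. It is the second group, after 2-methylphenyl, to clear the scatter against 4-cyanophenyl, with a 2.4-fold lower number from compound 1 to compound 4 (0.38 log units; beyond the scatter), a modest step close in size to a 2.5-fold lower number from compound 1 to compound 2 (0.40 log units; beyond the scatter); compound 3 stays within the scatter of compound 1. Nothing on hand explains these differences. The compounds shown carry only substituted phenyl groups on this nitrogen, so the effect of 4-methylphenyl, which would set methyl against methoxy on the same ring place, remains open. Also open, going by these compounds, is what a carboxylic acid or an amine on the phenyl ring would do to the number.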